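This account rests on a few compounds, and the source may have more. Where it says the series, first, only, none or still open, it means among the compounds named here.

Measured so far:
compound 1, `COc1ccc(S(=O)(=O)c2cnc3c(F)cccc3c2-c2cccc(F)c2)cc1`, 3.03 mL/min
compound 2, `COc1ccc(S(=O)(=O)c2cnc3cc(F)ccc3c2-c2ccc(F)cc2)cc1Cl`, 1.29 mL/min
compound 3, `O=S(=O)(c1ccc(F)cc1)c1cnc2c(F)cccc2c1-c1cccc(F)c1`, 1.56 mL/min

All three numbers come from an ADME assay on microsomes from liver (Homo sapiens) for metabolic stability, tested at 2.5 uM; a higher number here means faster removal of the compound, a lower number slower removal. Compound 1 and compound 3 share a core; the change between them is fluoro in place of methoxy on an aromatic carbon, which gave a 1.9-fold lower number from compound 1 to compound 3 (0.29 log units; within the scatter). Compound 2 stands nearest compound 3, with compound 1 further off. The difference between the core of compound 2 and that of compound 1 is not broken down here.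

Compound 4, `O=S(=O)(c1ccc(F)c(Cl)c1)c1cnc2cc(F)ccc2c1-c1ccc(F)cc1`, is not yet measured in this assay; it differs from compound 2 by fluoro in place of methoxy on an aromatic carbon. In compound 2 the place is also ortho to a chloro group, so this is the same kind of change as that between compound 1 and compound 3, not the same. From compound 2 to compound 4 a step of a 1.6-fold lower number from compound 2 to compound 4 (0.21 log units; within the scatter) is expected, of similar size because a 1.9-fold lower number from compound 1 to compound 3 (0.29 log units; within the scatter) came from the same kind of change. Compound 4 is estimated at 0.8 mL/min, between 0.4 mL/min and 1.6 mL/min.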

Compound 4, intrinsic clearance in a liver preparation (reported as CLH), per the amount of preparation that the assay uses: 0.69 mL/min
For compound 4 the middle estimate is 1.2-fold (0.06 log units) above the measured one, within the range that was stated.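

In this assay, fluoro in place of methoxy gives a 1.9-fold lower number from compound 2 to compound 4 (0.27 log units; within the scatter), and the change carries from one core to the other without a difference beyond the scatter: the same change on two cores in this assay, a 1.9-fold lower number (0.29 log units; within the scatter) from compound 1 to compound 3 and a 1.9-fold lower number (0.27 log units; within the scatter) from compound 2 to compound 4, 1.0-fold (0.02 log units) apart, within the scatter of two such steps. Each step alone lies within the scatter, so the pairs show agreement between the two cores, but neither pair on its own establishes a real effect of the change. Two cores are too few to show that the change would carry across the wider series, and the reason for the agreement remains unknown.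

Still open, on these data alone, is how other groups would behave at this place, such as an amine, a carboxylic acid or a longer chain. Also open is whether the step persists on a core without the fluoro groups shown here.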